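Shortening the pentyl chain in a furfurylamine series

This account rests on a few compounds, and the source may have more. Where it says the series, first, only, none or still open, it means among the compounds named here.

Working notes on a small set of quinazoline-free descriptors: three compounds sharing one core, assessed or to be assessed in a functional assay on HCT-116 cells (Homo sapiens) for cytotoxicity, read by MTT assay, with a stated time of 2 days; a lower number here means a stronger inhibitor, a higher number a weaker inhibitor. For the measured compounds named here, compound 1 `CCCCCNc1nc(NCc2ccco2)c2cc(F)ccc2n1` is the only member with a number: in this assay compound 1 gives 4100 nM. Compound 2 `CCCCCNc1nc(NCc2ccco2)c2ccccc2n1` is the closest relative to the new compound, but in this assay compound 2 gives "not determined" (no result reported), so no single number fixes where compound 2 stands, and the only anchor for the series is compound 1.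

Compound 3 `CCCCNc1nc(NCc2ccco2)c2ccccc2n1` follows from compound 2 by one change, (hydrogen in place of methyl on a saturated chain carbon, four bonds along the chain from a nitrogen on an aromatic ring). Going by the values given here, no step between measured compounds is available for this change, so its size in this assay cannot be read from the data; a small step, within the scatter or slightly toward weaker inhibition, is expected rather than a large one.

Compound 3 is therefore expected to give about 6000 nM in this assay, estimated between 2000 nM and 20000 nM.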

Compound 3, half-maximal inhibitory concentration: 5470 nM
Beside the measured number, compound 3's estimate is 1.1-fold (0.04 log units) above it, within the range that was stated.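

In this assay, for the compounds shown here, compound 2 has no single number, so no step from it to compound 3 can be read. The compounds shown leave open how large the change from methyl to hydrogen is in this series. No supporting data bearing on the result of compound 3 are available.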